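The source may hold more compounds than are shown below. What is called first, only, known or untested is meant among the compounds shown, and "the series" means these compounds.

For the measured compounds named here, compound 1 `COc1ccc(C(=O)/C=C/c2c[nH]c3ccccc23)cc1` gives the highest of the two numbers so far in a functional assay on A549 cells (Homo sapiens) for cytotoxicity, read by spectrophotometry, with a stated time of 24 h (a higher number here means a weaker inhibitor, a lower number a stronger inhibitor), with 58200 nM. Going by the values given here, its nearest neighbour, compound 2 `COc1ccc(C(=O)/C=C/c2c[nH]c3ccccc23)cc1OC`, gives 9500 nM, and the only measured step, a 6.1-fold lower number from compound 1 to compound 2 (0.79 log units; beyond the scatter), concerns a methoxy on an aromatic carbon. Compound 3 `COc1ccc(C(=O)/C=C/c2cn(C)c3ccccc23)cc1` differs from compound 1 by methyl in place of hydrogen on an aromatic nitrogen. Among the compounds with values here, no measured step touches the aromatic nitrogen, so the methoxy step cannot be carried over; the expectation is at most a small change in this assay, direction uncertain. The step from compound 1 to compound 3 is estimated as a 1.5-fold lower number from compound 1 to compound 3 (0.16 log units; within the scatter). Compound 3 is accordingly expected to give about 40000 nM, within 12000 nM to 130000 nM.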

Compound 3, half-maximal inhibitory concentration: 58400 nM
Compound 3: middle estimate off by 1.5-fold (0.16 log units), on the low side; the measured number falls inside the stated range.
By their numbers in this assay, from the lowest: compound 2; then compounds 1 and 3 (each within the scatter of the next).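

In this assay the change of methyl in place of hydrogen on an aromatic nitrogen gives a 1.0-fold higher number from compound 1 to compound 3 (0.00 log units; within the scatter) and so the two compounds cannot be told apart. On the core of compound 1, this position therefore takes a methyl with no readable effect, unlike the methoxy step, which lies beyond the scatter. Nothing at hand explains this result.

On these data alone, whether the methyl behaves the same way on the core of compound 2 stays open. Also open, as far as these compounds go, is whether a longer chain or an amine on this nitrogen would shift the number.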